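Chloro in place of fluoro: estimating compound 3

The compounds below may be only part of what the source reports. "The series", "measured", "known", "first", "only" and "open" are said of these compounds alone.

Measured in a functional assay on HGC cells (Homo sapiens) for cytotoxicity, read by MTT assay, with a stated time of 48 h; on this read-out higher numbers stand for weaker inhibition and lower numbers for stronger inhibition:
Compound 1 `Cn1c(/C=C2/C(=O)Nc3ccc(Br)cc32)nc2ccccc21`: > 50000 nM, a limit
Compound 2 `Cn1c(/C=C2/C(=O)Nc3ccc(F)cc32)nc2ccccc21`: 37800 nM

Compound 2 holds the only number shown in this assay. Compound 1 is reported only as the limit of > 50000 nM in this assay, at which 1 of the 2 values shown sits. Compound 3 `Cn1c(/C=C2/C(=O)Nc3ccc(Cl)cc32)nc2ccccc21` differs from compound 2 by chloro in place of fluoro on an aromatic carbon. Among the compounds with values here, the only measured step bearing on this change is an at least 1.3-fold lower number from compound 1 to compound 2 (0.12 log units; that floor lies within the scatter). Within the data shown here, with that small step as the sole guide, the expected step of a 1.1-fold higher number from compound 2 to compound 3 (0.05 log units; within the scatter) stays within the usual scatter, in no firm direction. The estimated value for compound 3 is 42000 nM, with an expected range from 22000 nM to 60000 nM.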

Compound 3, half-maximal inhibitory concentration: 43600 nM
Compound 3: the middle estimate sits 1.0-fold (0.02 log units) below what was measured, within the range that was stated.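

In this assay, within the data shown here, the only pair at this position with two actual numbers shows a 1.2-fold higher number from compound 2 to compound 3 (0.06 log units; within the scatter), so chloro in place of fluoro on this aromatic carbon has no clear effect on the read-out. The comparison with bromo gives only an at least 1.1-fold lower number from compound 1 to compound 3 (0.05 log units; that floor lies within the scatter), and no order among the three groups follows from it. Compound 1 is reported as a limit, not a number, so that step remains a floor: the limit of > 50000 nM in this assay, at which 1 of the 3 values shown sits.

The compounds shown leave open whether a group other than these three, such as an amine, a methoxy group or a carboxylic acid, would move the number at this position.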